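The source may hold more compounds than are shown below. What is called first, only, known or untested is meant among the compounds shown, and "the series" means these compounds.

Compound 1, `COc1ccccc1C(=O)NC(CC(=O)O)c1ccc(C(C)(C)C)cc1`: in a functional assay on MDA-MB-436 cells (Homo sapiens) for antiproliferative activity, read by MTT assay, with a stated time of 24 h (on this read-out lower numbers stand for stronger inhibition and higher numbers for weaker inhibition), compound 1 gives > 100000 nM, which is a limit of the assay rather than a number.
Compound 2, `COc1ccc(C(=O)NC(CC(=O)O)c2ccc(C(C)(C)C)cc2)cc1`: compound 2 gives > 100000 nM, again a limit.
Compound 3, `COc1ccc(C(=O)NC(CC(=O)O)c2ccc(Cl)cc2Cl)cc1`: compound 3 gives > 100000 nM, also a limit.

All three measured compounds share the same acid-bearing amide framework. The change from compound 2 to compound 1 is 2-methoxyphenyl in place of 4-methoxyphenyl on a carbonyl carbon. Its step, a step that the two limits leave unreadable from compound 2 to compound 1, has no readable size because the limit of > 100000 nM in this assay, at which 3 of the 3 values shown sit, covers both ends of it. Compound 4, `COc1ccccc1C(=O)NC(CC(=O)O)c1ccc(Cl)cc1Cl`, is made from compound 3 by the same change, (2-methoxyphenyl in place of 4-methoxyphenyl on a carbonyl carbon), at a place described in the same words. How the core of compound 3 differs from that of compound 2 is not broken down here.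

For the measured compounds named here, the step from compound 3 to compound 4 is expected to be a step that the limit leaves unreadable from compound 3 to compound 4, since the only earlier instance of this change left both compounds at the limit. Compound 4 is therefore expected to give about 150000 nM in this assay, most likely reported again only as a limit, within roughly 50000 nM to 500000 nM.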

Compound 4, half-maximal inhibitory concentration: > 100000 nM
Compound 4 gave a limit, no number; the forecaster's own chance of this, stated with the estimate: 85%; the middle value does not contradict the limit.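

Compound 3 and compound 4 both stand at a limit, not a number, so no size can be read for the step between them or for any other step here: the limit of > 100000 nM in this assay, at which 4 of the 4 values shown sit.

In this assay the compounds shown leave open whether 2-methoxyphenyl in place of 4-methoxyphenyl makes any difference at all, and which change to the shared core would give a readable value.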